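This account rests on a few compounds, and the source may have more. Where it says the series, first, only, none or still open, it means among the compounds named here.

Measured compounds:
compound 1 `O=c1ccc2cc(OCc3cc(-c4ccccc4)no3)ccc2o1`: 43300 nM in a functional assay on HL-60 cells (Homo sapiens) for cytotoxicity, read by MTT assay, with a stated time of 48 h; on this read-out higher numbers stand for weaker inhibition and lower numbers for stronger inhibition
compound 2 `COc1cccc(-c2cc(COc3ccc4oc(=O)ccc4c3)on2)c1`: "not determined" (no result reported) in this assay

Compound 2 stands nowhere on the numbers: in this assay compound 2 gives "not determined" (no result reported), so it cannot be set against compound 1, which in this assay gives 43300 nM. Compound 3 `O=c1ccc2cc(OCc3cc(-c4ccc([N+](=O)[O-])cc4)no3)ccc2o1` differs from compound 2 in a single place: 4-nitrophenyl in place of 3-methoxyphenyl on an aromatic carbon. Among the measured compounds shown here, no step between measured compounds is available, so the size and direction of this change cannot be read from the data; a shift beyond the scatter in either direction remains possible, and none is assumed. Compound 3 is expected to give about 30000 nM in this assay, estimated within 8000 nM to 120000 nM.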

Compound 3, half-maximal inhibitory concentration: 55800 nM
Estimate against measurement, compound 3: 1.9-fold (0.27 log units) below; measured number inside the range.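

In this assay putting nitro on the phenyl ring gives a 1.3-fold higher number from compound 1 to compound 3 (0.11 log units; within the scatter) and so, at this place on the five-membered ring, 4-nitrophenyl and unsubstituted phenyl cannot be told apart. Compound 2 has no number, so the step from it to compound 3 cannot be read. No measurement shown offers an explanation for this result. Still open, from the compounds shown here alone, is whether an amine or a carboxylic acid on that phenyl ring, or a longer chain in place of the ring, would move the number beyond the scatter.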